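Oxetane for methyl on the pyrazole nitrogen

The source may report more compounds than this note shows. Statements on the series, on what has been measured and on what is new or still open speak of the compounds shown alone.

Measured compounds:
compound 1, `Cc1c(Nc2nc(N)c3c(C#N)c(N4CCC[C@H]4C)n(C)c3n2)cnn1C`: in an assay on isolated protein for inhibition of Leucine-rich repeat serine/threonine-protein kinase 2 (Homo sapiens), read by TR-FRET and LanthaScreen, with stated times of 50 min and 30 min, in the presence of a further agent that is not named here (on this read-out higher numbers stand for weaker inhibition and lower numbers for stronger inhibition), compound 1 gives 75 nM
compound 2, `CN(C)c1c(C#N)c2c(N)ncnc2n1C`: in this assay compound 2 gives 4620 nM
compound 3, `C[C@@H]1CCCN1c1cc2c(N)ncnc2n1C`: in this assay compound 3 gives 6830 nM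

Compound 1 has the lowest number of the three in this assay, and both of its steps to the others are beyond the scatter; compound 2 is the nearer of the two, compound 3 the further. Going by the values given here, compound 2 and compound 3 are smaller fragments of the shared core, and no single-point step between any two measured compounds is available, so nothing here reports how the group on the pyrazole nitrogen behaves.

The next compound, compound 4 `Cc1c(Nc2nc(N)c3c(C#N)c(N4CCC[C@H]4C)n(C)c3n2)cnn1C1COC1`, differs from compound 1 only in one place: oxetan-3-yl in place of methyl on an aromatic nitrogen. The change sits on an aromatic nitrogen of a five-membered aromatic ring with 2 nitrogen, two ring bonds from the ring atom that bears a large group, and introduces one hydrogen-bond acceptor in a four-membered non-aromatic ring.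

Among the compounds with values here, with no matching step on record, the step of a 1.3-fold lower number from compound 1 to compound 4 (0.10 log units; within the scatter) is expected to stay within the scatter, in either direction. Compound 4 is therefore estimated at 60 nM, with a range of 20 nM to 200 nM.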

Compound 4, half-maximal inhibitory concentration: 47 nM
Compound 4: the middle estimate sits 1.3-fold (0.11 log units) above what was measured, and the stated range covers the measured number.
By their numbers in this assay, from the lowest: compounds 4 and 1 (each within the scatter of the next); then compounds 2 and 3 (each within the scatter of the next).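

In this assay, going by these compounds alone, oxetan-3-yl in place of methyl on the aromatic nitrogen gives the first single-point reading at this position (a 1.6-fold lower number from compound 1 to compound 4 (0.20 log units; within the scatter)). The four-membered non-aromatic ring and its hydrogen-bond acceptor therefore enter the pyrazole nitrogen without a step beyond the scatter, and this read-out does not separate the two groups. No measurement at hand gives a reason for this result.

From the compounds shown here alone, this one step fixes a single point at the position, so it remains open how an amine such as a piperidin-4-yl group, a carboxylic acid or a longer chain such as 2-methoxyethyl would read there. Also open, going by these compounds, is whether the same step holds when hydrogen replaces the methyl group on the ring atom that bears it.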